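This account rests on a few compounds, and the source may have more. Where it says the series, first, only, none or still open, it means among the compounds named here.

Measured so far in this study:

- compound 1, `CC(C)[C@@H]1CC[C@@H](C)C[C@@]12N(C)C(=O)[C@@H]1[C@H]3C(=O)N(c4ccccc4)C(=O)[C@H]3ON12`: 14.7%
- compound 2, `CC(C)[C@@H]1CC[C@@H](C)C[C@@]12N(C)C(=O)[C@@H]1[C@H]3C(=O)N(c4ccc(Cl)cc4)C(=O)[C@H]3ON12`: 29.7%

In a functional assay, read by spectrophotometry, with a stated time of 2 h, tested at 0.5 mg/mL (on this read-out lower numbers stand for a weaker effect and higher numbers for a stronger effect at the one concentration tested), compound 1 gives 14.7% and compound 2 gives 29.7%. Compound 2 thus stands highest of the two numbers, its nearest neighbour being compound 1, whose number is lower by the step of a number 15 percentage points higher from compound 1 to compound 2 (beyond the scatter). Going by the values given here, that single step, chloro in place of hydrogen on an aromatic carbon, is the only measured change, and it was modest.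

Compound 3, `Cc1ccc(N2C(=O)[C@H]3[C@H](ON4[C@@H]3C(=O)N(C)[C@@]43C[C@H](C)CC[C@H]3C(C)C)C2=O)c(C)c1`, has not yet been measured in this assay. It differs from compound 2 in one place: 2,4-dimethylphenyl in place of 4-chlorophenyl on an amide-type nitrogen in a ring. Among the compounds with values here, no measured pair shows a 2,4-dimethylphenyl, so the step from compound 1 to compound 2 bears on it only loosely, as a sign that changing this aryl group can move the number by a modest amount. With nothing firmer to go on, compound 3 is expected to sit near compound 2, a step of about a number 2.7 percentage points lower from compound 2 to compound 3 (within the scatter), likely within the scatter. The estimated value for compound 3 is therefore 27%, with a range from 12% to 44%.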

Compound 3, a percentage reported as activity, at one concentration (the size of the read-out at that concentration, not a potency): 52.9%
The estimate for compound 3 lay 25.9 percentage points below the measured number; measured number outside the range, above it.
By their numbers in this assay, from the lowest: compound 1; then compound 2; then compound 3.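

In this assay, 2,4-dimethylphenyl on the amide-type nitrogen in a ring gives a number 23.2 percentage points higher from compound 2 to compound 3 (beyond the scatter), and the same group gives a number 38.2 percentage points higher from compound 1 to compound 3 (beyond the scatter). The position therefore tolerates more than a chloro swap on the aromatic ring and can carry a much larger change in the read-out than a number 15 percentage points higher from compound 1 to compound 2 (beyond the scatter) had suggested, with an aryl group bearing no chlorine giving the highest number of the three. Nothing available accounts for this rise at this position.

The compounds shown leave open whether one methyl group alone, as in 4-methylphenyl or 2-methylphenyl, would give this rise or whether both are needed. They also leave open how other groups at this nitrogen would read, such as 2,4-dichlorophenyl, a methoxy-bearing phenyl or a benzyl.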